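Aryl swap on the shared core: outlook for compound 4

This account rests on a few compounds, and the source may have more. Where it says the series, first, only, none or still open, it means among the compounds named here.

Within the data shown here, compound 3 `O=C(NO)c1ccc(NCc2nc(-c3ccsc3)nn2-c2ccccc2)cc1` gives 53.4% in an assay on Sf9 cells for inhibition of protein deacetylase HDAC6 (Homo sapiens), read by fluorescence, with a stated time of 40 min, tested at 100 nM (on this read-out lower numbers stand for less inhibition and higher numbers for more inhibition at the one concentration tested (going by the name of the read-out)), the lowest of the three numbers so far. Compound 2 `CCc1ccc(-c2nc(CNc3ccc(C(=O)NO)cc3)n(-c3ccccc3)n2)cc1` gives 54.6%, within the scatter of compound 3, while compound 1 `Cc1ccc(-c2nc(CNc3ccc(C(=O)NO)cc3)n(-c3ccccc3)n2)s1` gives 79.7%, and the step of a number 26.3 percentage points lower from compound 1 to compound 3 (beyond the scatter) lies beyond the scatter. Compound 4 `CC(C)c1ccc(-c2nc(CNc3ccc(C(=O)NO)cc3)n(-c3ccccc3)n2)cc1` differs from compound 3 by 4-isopropylphenyl in place of thiophen-3-yl on an aromatic carbon. The measured step that bears on this is a number 1.2 percentage points lower from compound 2 to compound 3 (within the scatter), which stayed within the scatter, so returning to a six-membered ring of carbon only should cost little. Among the measured compounds shown here, no measured pair separates 4-isopropylphenyl from 4-ethylphenyl, so that part of the change is unknown. The step of a number 1.6 percentage points higher from compound 3 to compound 4 (within the scatter) is therefore expected to stay within the scatter. The estimate for compound 4 is 55%, with a range from 40% to 70%.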

Compound 4, a percentage reported as inhibition, at one concentration (the size of the read-out at that concentration, not a potency): 27.6%
Compound 4: middle estimate off by 27.4 percentage points, on the high side; measured number outside the range, below it.
By their numbers in this assay, from the lowest: compound 4; then compounds 3 and 2 (each within the scatter of the next); then compound 1.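

One methyl in place of hydrogen on the saturated chain carbon gives a number 27 percentage points lower from compound 2 to compound 4 (beyond the scatter) in this assay, so the number at this position can move with a change this small, which the earlier pair of 4-ethylphenyl and thiophen-3-yl did not reveal. Replacing thiophen-3-yl with 4-isopropylphenyl gives a number 25.8 percentage points lower from compound 3 to compound 4 (beyond the scatter), and replacing 5-methylthiophen-2-yl with it gives a number 52.1 percentage points lower from compound 1 to compound 4 (beyond the scatter). No supporting measurement accounts for these steps.

Open, on these data alone, is whether 4-tert-butylphenyl would read lower still. Also open, as far as these compounds go, is how an amine or a carboxylic acid in place of the isopropyl group would read.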